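Propargyloxy in place of propoxy on an aminated core

The compounds below may be only part of what the source reports. "The series", "measured", "known", "first", "only" and "open" are said of these compounds alone.

Compound 1 `O=c1[nH]c(-c2ccccc2)cn2c(=O)n(-c3ccccc3)nc12` is the only one of the two measured compounds with a number rather than a limit. In an assay on cells for displacement of a labelled ligand from adenosine receptor A3 (Homo sapiens), read by scintillation counting, with a stated time of 3 h (a lower number here means a stronger inhibitor, a higher number a weaker inhibitor), compound 1 gives 96 nM. Compound 2 `CCCOc1ccc(-c2cn3c(=O)n(-c4ccccc4)nc3c(N)n2)cc1` carries an amino group on the core and a propoxy chain on the outer phenyl ring. In this assay compound 2 reaches only a limit of > 30000 nM, as one of the two values sits at the limit of > 30000 nM in this assay, at which 1 of the 2 values shown sits. Compound 3 `C#CCOc1ccc(-c2cn3c(=O)n(-c4ccccc4)nc3c(N)n2)cc1` differs from compound 2 only in that chain: ethynyl in place of ethyl on a saturated chain carbon bound to an oxygen on an aromatic ring. For the measured compounds named here, no step between measured compounds is known, so the expectation rests on compound 2 alone, which already sits at the limit in this assay with > 30000 nM. The step of a number no higher from compound 2 to compound 3 (the limit leaves the size open) is therefore expected to be none beyond the scatter. Compound 3 is expected to give about 30000 nM in this assay, between 5000 nM and 100000 nM, most likely again reported only as a limit.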

Compound 3, inhibition constant: > 30000 nM
Compound 3 ended at the assay's limit; the forecaster's own chance of this, stated with the estimate: 70%; the middle value sits exactly at the limit.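

Compound 2 and compound 3 are each reported only as a limit in this assay, so no step between them can be read: the limit of > 30000 nM in this assay, at which 2 of the 3 values shown sit.

The compounds shown leave open whether propargyloxy in place of propoxy changes the inhibition constant at all, and what actual number either compound would give.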